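From Propyl to 3-Chloropropyl in Compound 3

The source may report more compounds than this note shows. Statements on the series, on what has been measured and on what is new or still open speak of the compounds shown alone.

In a functional assay on MDA-MB-231 cells (Homo sapiens) for antiproliferative activity, read by sulforhodamine B assay, with a stated time of 48 h (a higher number here means a weaker inhibitor of growth, a lower number a stronger inhibitor of growth), compound 3 `CCCc1cn(CCCN2C(=O)COc3ccccc32)nn1` gives 1100 nM, level with compound 1 `Cc1ccc(-c2cn(CCCN3C(=O)COc4ccccc43)nn2)cc1` at 1120 nM, while compound 2 `O=C1COc2ccccc2N1CCCn1cc(-c2cccnc2)nn1` gives 3000 nM. Compound 4 `O=C1COc2ccccc2N1CCCn1cc(CCCCl)nn1` carries chloro in place of hydrogen on a saturated chain carbon, three bonds along the chain from an aromatic carbon, so that propyl becomes 3-chloropropyl: chloro in place of hydrogen on a saturated chain carbon, three bonds along the chain from an aromatic carbon. For the measured compounds named here, no measured step alters that chain itself. Exchanging the whole group on the aromatic carbon gave a 1.0-fold lower number from compound 1 to compound 3 (0.01 log units; within the scatter) and a 2.7-fold lower number from compound 2 to compound 3 (0.44 log units; beyond the scatter), so only a small change, none beyond the scatter, is expected in this assay. The expected step is a 1.1-fold lower number from compound 3 to compound 4 (0.04 log units; within the scatter). Compound 4 is estimated at 1000 nM, within a range of 450 nM to 2400 nM.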

Compound 4, concentration for 50% growth inhibition: 6400 nM
For compound 4 the middle estimate is 6.4-fold (0.81 log units) below the measured one; measured number outside the range, above it.
By their numbers in this assay, from the lowest: compounds 3 and 1 (each within the scatter of the next); then compound 2; then compound 4.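

In this assay, a single chloro on a saturated chain carbon, three bonds along the chain from an aromatic carbon, gives a 5.8-fold higher number from compound 3 to compound 4 (0.76 log units; beyond the scatter), the first measured change within that chain. The other two steps, a 2.1-fold higher number from compound 2 to compound 4 (0.33 log units; beyond the scatter) and a 5.7-fold higher number from compound 1 to compound 4 (0.76 log units; beyond the scatter), place compound 4 with the highest number of the four, so this chain position responds to a small change. Nothing available explains this step.

From the compounds shown here alone, whether the rise is specific to chloro remains open. A hydroxyl or an amine at the same carbon, or a longer chain ending in chloro, could test that.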